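The source may hold more compounds than are shown below. What is called first, only, known or untested is meant among the compounds shown, and "the series" means these compounds.

Measured so far in a physicochemical assay for lipophilicity; a higher number here means a more lipophilic compound, a lower number a more polar compound:
compound 1 `O=C1/C(=C/c2ccccc2)CCC/C1=C\c1cccc([N+](=O)[O-])c1` gives 5.06;
compound 2 `Cc1ccc(/C=C2\CCC/C(=C\c3ccccc3[N+](=O)[O-])C2=O)cc1` gives 4.86;
compound 3 `Cc1ccc(/C=C2\CCC/C(=C\c3ccc([N+](=O)[O-])cc3)C2=O)cc1` gives 5.08.

On these three numbers compound 2 does not stand apart: its nearest neighbour is compound 1, whose number lies within the scatter of it, and the furthest is compound 3, whose number also lies within the scatter. Among the compounds with values here, no pair among the three differs in only one place, so no single step from measured to measured compound can be read off in this assay; the three values simply sit together as a cluster.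

Compound 4 `O=C1/C(=C/c2ccc(Cl)cc2)CCC/C1=C\c1ccccc1[N+](=O)[O-]` is the next candidate and is not yet measured. It differs from compound 2 in one place: chloro in place of methyl on an aromatic carbon.

Within the data shown here, with no measured step to lean on, the expectation can rest only on the change itself and on how close the three measured numbers already are. The step from compound 2 to compound 4 is expected to be small, leaning toward a higher number, and not beyond the scatter, at a number 0.14 log units higher from compound 2 to compound 4 (within the scatter). Compound 4 is therefore estimated to give 5 in this assay, with a range from 4.6 to 5.4.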

Compound 4, partition coefficient: 4.86
The estimate for compound 4 lay 0.14 log units above the measured number; the measured number falls inside the stated range.
By their numbers in this assay, from the lowest: compounds 2, 4, 1 and 3 (each within the scatter of the next).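

Chloro in place of methyl, on an aromatic carbon para to a large group, is the first change in this series that can be read on its own, and in this assay the 4-methylphenyl to 4-chlorophenyl exchange gives no change at the digits printed from compound 2 to compound 4 (within the scatter). The earlier compounds shown here could not show this, since each pair among them differs in more than one place and their numbers could only be set side by side. At this position, with the rest of compound 2 held fixed, the measurement does not tell the two groups apart, and nothing at hand bears on why that should be so.

Still open, going by these compounds, is whether a group of a different kind on the same aromatic carbon, such as an amine, a carboxylic acid or a longer alkyl chain, would carry the number beyond the scatter in this assay. Also open, on these data alone, is whether the 4-methylphenyl to 4-chlorophenyl exchange would read the same on the core of compound 3, since a single step on one core cannot stand for the whole series.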